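Cytotoxicity of a dichlorophenyl analogue on HepG2 cells

The compounds below may be only part of what the source reports. "The series", "measured", "known", "first", "only" and "open" are said of these compounds alone.

Three compounds built on one shared core have been examined in an ADME assay on HepG2 cells (Homo sapiens) for cytotoxicity, read by CellTiter-Glo and resazurin assay, with a stated time of 72 h; on this read-out lower numbers stand for an effect already at smaller amounts and higher numbers for an effect only at larger amounts of compound. Compound 1 `CCOC(=O)CCCCCOc1cccc(CN(C(=O)c2ccc(-c3ccoc3)cc2)C(C)C)c1` carries a furan-3-yl group. In this assay compound 1 gives only the limit > 26000 nM. Compound 2 `CCOC(=O)CCCCCOc1cccc(CN(C(=O)c2ccc(-c3ccco3)cc2)C(C)C)c1` has furan-2-yl in place of furan-3-yl on an aromatic carbon. In this assay compound 2 likewise gives only the limit > 26000 nM. Compound 3 `CCOC(=O)CCCCCOc1cccc(CN(C(=O)c2ccc(-c3cccc(OC)c3)cc2)C(C)C)c1` carries 3-methoxyphenyl at the same aromatic carbon. In this assay compound 3 gives only the limit > 21000 nM. Compound 3 therefore stands at the limit of > 21000 nM in this assay, at which 1 of the 3 values shown sits. The other two values rest at the limit of > 26000 nM in this assay, at which 2 of the 3 values shown sit. Among the measured compounds shown here, none of the measured steps can be read in size: a step that the two limits leave unreadable from compound 1 to compound 2, a step that the two limits leave unreadable from compound 1 to compound 3 and a step that the two limits leave unreadable from compound 2 to compound 3 each compare two limits, so no direction emerges from them.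

Compound 4 `CCOC(=O)CCCCCOc1cccc(CN(C(=O)c2ccc(-c3ccc(Cl)c(Cl)c3)cc2)C(C)C)c1` is the next member, with the change (3,4-dichlorophenyl in place of 3-methoxyphenyl on an aromatic carbon). For the measured compounds named here, no readable step bears on this change, and every value so far is a limit. The author therefore expects the step that the limit leaves unreadable from compound 3 to compound 4 to be small or again unreadable. Compound 4 is estimated at 25000 nM, with a range from 8000 nM to 60000 nM, and is most likely to be reported once more as a limit.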

Compound 4, half-maximal effective concentration: > 26000 nM
Compound 4 ended at the assay's limit; the forecaster's own chance of this, stated with the estimate: 75%; middle value at least 1.0-fold (0.01 log units) away from the limit.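

Compound 4, like compound 1, compound 2 and compound 3, gives only a limit in this assay, so none of its steps to those three compounds can be read in size. The compounds shown leave open where the half-maximal effective concentration of any of the four lies, and whether the group on that aromatic carbon affects it.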